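The source may hold more compounds than are shown below. What is called first, only, known or untested is meant among the compounds shown, and "the series" means these compounds.

Working notes on the series. Three members have been measured in an ADME assay on Vero cells (Chlorocebus sabaeus) for cytotoxicity, read by neutral red uptake, tested at 394 ug/mL; a higher number here means a weaker effect of the compound at the concentration tested, a lower number a stronger effect. Compound 1, `O=C1CSC(c2c(Cl)cccc2Cl)N1CCN1CCCCC1`, gives 32% in this assay. Compound 2, `O=C1CSC(c2cccc(Cl)c2)N1CCN1CCCCC1`, gives 45% in this assay. Compound 3, `O=C1CSC(c2ccccc2[N+](=O)[O-])N1CCN1CCCCC1`, gives 100% in this assay. Within these three numbers compound 2 holds the second highest place; its nearest neighbour is compound 1, whose number is lower by a gap that lies beyond the scatter, and its furthest is compound 3, whose number is higher by a gap far beyond the scatter. Among the measured compounds shown here, no step between two measured compounds that differ in only one place is available, so the measured set gives no direct calibration for a single exchange on the aromatic ring.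

Compound 4, `Cc1ccc(C2SCC(=O)N2CCN2CCCCC2)cc1`, has not yet been measured in this assay. Relative to compound 2 it carries 4-methylphenyl in place of 3-chlorophenyl on a saturated ring carbon. For the measured compounds named here, with no comparable measured step to lean on, the expectation for this exchange is a modest change, if any, with the number of compound 4 held near that of compound 2 and a slight lean toward the higher side; the expected step is a number 7 percentage points higher from compound 2 to compound 4 (within the scatter). On that basis compound 4 is estimated to give 52% in this assay, with a range from 30% to 80%.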

Compound 4, a percentage reported as activity, at one concentration (the size of the read-out at that concentration, not a potency): 51%
The estimate for compound 4 lay 1 percentage points above the measured number; the measured number falls inside the stated range.
By their numbers in this assay, from the lowest: compound 1; then compounds 2 and 4 (each within the scatter of the next); then compound 3.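

Among the compounds shown here, the exchange of 3-chlorophenyl for 4-methylphenyl on a saturated ring carbon provides the first single-place step in this assay, a number 6 percentage points higher from compound 2 to compound 4 (within the scatter), so compound 2 and compound 4 cannot be told apart at this concentration. For the compounds shown here, at this position, therefore, this one exchange of aromatic group leaves the read-out within the usual scatter of repeated measurements, which the earlier compounds, with no step between them, could not show. The exchange alters both the substituent and its place on the phenyl ring, so the step describes the two changes only together, and no supporting measurement bears on the result.

Going by these compounds, it remains open whether the substituent or its place on the phenyl ring matters more, and whether the same tolerance would hold for a plain phenyl or for a phenyl carrying an amine or a carboxylic acid. This single step also says nothing about exchanges elsewhere on the shared core, or about how far it would carry over to other aromatic groups at this position.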